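Methoxy in place of hydrogen: expected step from compound 2

This account rests on a few compounds, and the source may have more. Where it says the series, first, only, none or still open, it means among the compounds named here.

In an ADME assay for pharmacokinetics (a higher number here means that the compound lasts longer, a lower number that the compound disappears faster), compound 2 `NC(=O)c1ncn2c(=O)n(-c3ccccc3)nnc12` gives 0.383 h as its reading. Compound 3 `Cc1ccc(-n2nnc3c(C(N)=O)ncn3c2=O)cc1` gives 0.667 h and lies within the scatter of compound 2, while compound 1 `N#Cc1cccc(-n2nnc3c(C(N)=O)ncn3c2=O)c1` gives 0.0433 h and lies well clear of compound 2 on the low side. Compound 2 therefore stands level with compound 3 and clear of compound 1.

Compound 4 `COc1ccc(-n2nnc3c(C(N)=O)ncn3c2=O)cc1` differs from compound 2 by methoxy in place of hydrogen on an aromatic carbon in one place: methoxy in place of hydrogen on an aromatic carbon, para to a large group. Among the measured compounds shown here, no compound with methoxy has been measured yet. The closest guide is compound 3, with methyl in place of hydrogen on an aromatic carbon, and that step is small: a 1.7-fold higher number from compound 2 to compound 3 (0.24 log units; within the scatter) is all it amounts to. The other step is an 8.8-fold higher number from compound 1 to compound 2 (0.95 log units; beyond the scatter) and concerns hydrogen in place of cyano, a different group, so it widens the expected range without setting a direction.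

The expected outcome is a 1.3-fold higher number from compound 2 to compound 4 (0.12 log units; within the scatter) as an estimate, with no change beyond the scatter expected. For compound 4 the estimated value is 0.5 h with an expected range from 0.2 h to 1.2 h as the likely span.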

Compound 4, half-life: 1.15 h
Beside the measured number, compound 4's estimate is 2.3-fold (0.36 log units) below it; the range from low to high includes it.
By their numbers in this assay, from the lowest: compound 1; then compounds 2, 3 and 4 (each within the scatter of the next, the first and the last beyond it).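

In this assay, methoxy in place of hydrogen on an aromatic carbon, para to a large group, gives a 3.0-fold higher number from compound 2 to compound 4 (0.48 log units; beyond the scatter), so this position on the ring does respond to a substituent, which the methyl step alone, a 1.7-fold higher number from compound 2 to compound 3 (0.24 log units; within the scatter), could not show. Methoxy and methyl at this position remain unresolved from each other, with a 1.7-fold higher number from compound 3 to compound 4 (0.24 log units; within the scatter), so the series can separate methoxy from hydrogen but cannot rank methoxy against methyl. Among the compounds shown here, nothing measured so far bears on why the half-life responds to this change.

On these data alone, it remains open whether the response continues with a longer alkoxy chain such as ethoxy or butoxy, or whether it is particular to methoxy and would also appear with an amine or a hydroxyl group in the same place. A carboxylic acid or a chlorine atom there would show whether the number can also fall at this position, since neither methyl nor methoxy gives a reading clearly under that of compound 2.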